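This account rests on a few compounds, and the source may have more. Where it says the series, first, only, none or still open, it means among the compounds named here.

Measured compounds:
- Compound 1, `CC(C)(C)/N=c1\c(O)c(O)\c1=N/Cc1ccc(F)cc1F`: 2100 nM
- Compound 2, `CC(C)(C)/N=c1\c(O)c(O)\c1=N/Cc1ccccc1F`: 2100 nM
- Compound 3, `CCCC(=O)N(Cc1ccc(C#N)cc1)c1c(NC(C)C(C)(C)C)c(=O)c1=O`: 12200 nM

In a functional assay for inhibition, with Rattus norvegicus as the target (on this read-out lower numbers stand for stronger inhibition and higher numbers for weaker inhibition), compound 1 gives 2100 nM. Compound 2 gives 2100 nM, level with compound 1 at the digits printed; together these two are the lowest of the three numbers. Compound 3, built on a different core, gives 12200 nM, a number well beyond the scatter from compound 1.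

Compound 4, `CC(C)(C)/N=c1\c(O)c(O)\c1=N/Cc1ccc(F)cc1Cl`, differs from compound 1 in one place: chloro in place of fluoro on an aromatic carbon. The change sits on an aromatic carbon of a six-membered aromatic ring of carbon only, ortho to a large group and meta to a fluoro group.

Among the measured compounds shown here, one measured step bears on this position. Going from compound 1 to compound 2, hydrogen in place of fluoro on an aromatic carbon gave no change at the digits printed from compound 1 to compound 2 (within the scatter). That position therefore seems to accept a small change without the number moving beyond the scatter, though a chloro group has not itself been tried. On that basis compound 4 is expected to land close to compound 1, with a step of a 1.2-fold lower number from compound 1 to compound 4 (0.07 log units; within the scatter). The estimate for compound 4 is 1800 nM, with a range from 700 nM to 5000 nM.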

Compound 4, half-maximal inhibitory concentration: 1400 nM
Compound 4: the middle estimate sits 1.3-fold (0.11 log units) above what was measured, and the stated range covers the measured number.
By their numbers in this assay, from the lowest: compounds 4, 1 and 2 (each within the scatter of the next); then compound 3.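

Among the compounds shown here, the earlier step from compound 1 to compound 2 removed the other fluoro on the ring, so this is the first reading at this aromatic carbon, the one ortho to a large group. In this assay, swapping fluoro for chloro here gives a 1.5-fold lower number from compound 1 to compound 4 (0.18 log units; within the scatter) and so leaves the number inside normal repeat variation, which means this carbon has accepted either halogen without a measurable difference. Nothing available here explains that outcome.

Going by these compounds, what stays open is how far this tolerance extends, since only fluoro and chloro appear at this carbon. Whether hydrogen, a methoxy group, an amine or a carboxylic acid would also leave the number in place cannot be told from these compounds.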